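Chloropropyl amide to acrylamide on the aryl amide

This account rests on a few compounds, and the source may have more. Where it says the series, first, only, none or still open, it means among the compounds named here.

Among the measured compounds shown here, compound 2 `CCCCC(O)c1cccc(NC(=O)CCCCl)c1` is the weaker of the two measured members. In a functional assay on HT-29 cells (Homo sapiens) for antiproliferative activity, with a stated time of 48 h (a lower number here means a stronger inhibitor, a higher number a weaker inhibitor), compound 2 reaches only the limit of > 100000 nM, which is a limit of the assay and not a number. Compound 1 `CCCCC(O)c1cccc(NC(=O)NC(=O)CCl)c1` gives 10000 nM in this assay. For the measured compounds named here, the one measured step, an at least 10-fold higher number from compound 1 to compound 2 (1.00 log units; beyond the scatter), ends at that limit (the limit of > 100000 nM in this assay, at which 1 of the 2 values shown sits), so its true size is not known beyond that.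

Compound 3 `C=CC(=O)Nc1cccc(C(O)CCCC)c1` differs from compound 2 by vinyl in place of 3-chloropropyl on a carbonyl carbon. Going by the values given here, no measured step covers this change directly; the step from compound 1 to compound 2 concerns a different part of the chain and only shows that the chloropropyl amide sits at the limit. Since compound 2 sits at a limit, any number that is obtained for compound 3 would count as a lower number, and a step of an at least 5.0-fold lower number from compound 2 to compound 3 (0.69 log units; beyond the scatter) is expected, toward a stronger inhibitor, though a further limit remains possible. For compound 3 the estimate in this assay is 20000 nM, with a range from 3000 nM to 100000 nM.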

Compound 3, half-maximal inhibitory concentration: > 100000 nM
Compound 3: only a limit was reported (the forecaster's own chance of this, stated with the estimate: 35%); middle value at least 5.0-fold (0.69 log units) from the limit.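

In this assay compound 3 gives > 100000 nM, which is a limit of the assay and not a number. The step between the two amides cannot be read, as both ends are limits, so vinyl in place of 3-chloropropyl on a carbonyl carbon gives no readable change in this assay, and the vinyl amide adds no second number to the series. On the other side there is an at least 10-fold higher number from compound 1 to compound 3 (1.00 log units; beyond the scatter), which ends at a limit just as the step to compound 2 does, so compound 1 remains the only member with a readable number and the two simple amides share the same limit: the limit of > 100000 nM in this assay, at which 2 of the 3 values shown sit.

Any difference between the vinyl and 3-chloropropyl groups at this place remains hidden behind the limit. Also open, on these data alone, is whether a chloroacetyl amide or a plain acetyl amide on the shared core would give a readable number, which would show whether the readable value of compound 1 goes with the chloromethyl group or with the longer ((chloromethyl)carbonyl)amino unit.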